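The source may hold more compounds than are shown below. What is called first, only, known or untested is meant among the compounds shown, and "the series" means these compounds.

Compound 1 `CC(C)(C)c1ccc(C(=O)NCc2ccc(-c3nnn[nH]3)cc2)cc1` and compound 2 `CC(C)(C)c1ccc(C(=O)NCc2ccc(N)cc2Cl)cc1` share a core and differ only in the group that sits on it. In an assay on HeLa cells with Bile acid receptor (Homo sapiens) as the target, read by a luciferase reporter, with a stated time of 24 h (a higher number here means that more compound is needed for the effect, a lower number that less compound is needed), compound 1 gives 120 nM, the higher of the two numbers, while compound 2 gives 46 nM; the gap between them lies beyond the usual scatter, so compound 2 needs less material for the same effect. Compound 3 `CC(C)(C)c1ccc(C(=O)NCc2ccc(S(N)(=O)=O)cc2)cc1`, not yet measured, keeps the core of compound 1 and differs from it in one place: sulfamoyl in place of 1H-tetrazol-5-yl on an aromatic carbon. Among the measured compounds shown here, no pair of measured compounds shows what this exchange does, so the expectation rests on the values at hand alone. The step expected from compound 1 to compound 3 in this assay is a 1.8-fold higher number from compound 1 to compound 3 (0.26 log units; within the scatter), a modest move toward a higher number, not far outside the scatter. Compound 3 is therefore estimated at 220 nM, with a range from 60 nM to 800 nM.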

Compound 3, half-maximal effective concentration: 1400 nM
Beside the measured number, compound 3's estimate is 6.4-fold (0.80 log units) below it, outside the stated range (above it).
By their numbers in this assay, from the lowest: compound 2; then compound 1; then compound 3.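

In this assay the exchange of 1H-tetrazol-5-yl for sulfamoyl, on an aromatic carbon para to a large group, gives a 12-fold higher number from compound 1 to compound 3 (1.07 log units; beyond the scatter) and so shows that this position is far from indifferent to the group it carries. Both groups count one hydrogen-bond donor and no net charge, so a match in those counts does not ensure a similar number here. No measurement on these compounds accounts for the size of this step.

As far as these compounds go, whether a carboxylic acid or an amide at this place would give a number nearer that of compound 1 or that of compound 3 remains open. Also open, from the compounds shown here alone, is whether a methyl group on the sulfamoyl nitrogen would change the result.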